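A few compounds are considered here, and "the series" means these few. Any claim that something is new, unique, unknown or untested is made for them only; others in the source may bear on it.

Compound 1 `C/C(=C\c1cc(-c2ccc(F)cc2)cs1)C(N)=O` was tested in an ADME assay on NIH3T3 cells (Mus musculus) for cytotoxicity, read by CCK-8 assay, with a stated time of 24 h; a lower number here means a stronger inhibitor, a higher number a weaker inhibitor. In this assay compound 1 gives > 50000 nM, which is a limit of the assay rather than a number. Compound 2 `C/C(=C\c1nc(-c2ccc(F)cc2)cs1)C(N)=O` in this assay gives > 50000 nM, likewise a limit. So compound 1 stands at the limit of > 50000 nM in this assay, at which 2 of the 2 values shown sit, with no number to place it more finely. Compound 3 `C=Cc1ccc(-c2csc(/C=C(\C)C(N)=O)c2)cc1` differs from compound 1 by vinyl in place of fluoro on an aromatic carbon. Going by the values given here, no measured step covers this change. The step is expected to be a step that the limit leaves unreadable from compound 1 to compound 3, nothing beyond the scatter. Compound 3 is estimated at 80000 nM, between 20000 nM and 300000 nM, most likely again reported as a limit.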

Compound 3, half-maximal inhibitory concentration: > 50000 nM
Compound 3: no number, only a limit; the forecaster's own chance of this, stated with the estimate: 85%; the middle value lies beyond the limit too.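

Compound 1 and compound 3 both stop at a limit in this assay, so no step between them can be read: the limit of > 50000 nM in this assay, at which 3 of the 3 values shown sit.

As far as these compounds go, whether vinyl in place of fluoro changes the value at all stays open, as does the concentration at which compound 1, compound 2 or compound 3 would reach half-maximal inhibition.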